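A Ring Amine in Place of Isopropylamino on the Shared Core

The source may hold more compounds than are shown below. What is called first, only, known or untested is meant among the compounds shown, and "the series" means these compounds.

Of the compounds shown here, three have so far been measured in a functional assay on RAW264.7 cells (Mus musculus) for inhibition, read by Griess assay, with stated times of 1 h and 24 h; a lower number here means a stronger inhibitor, a higher number a weaker inhibitor. Compound 1 `CCCc1nn(C)c2c(NC(C)C)nc(-c3cc(OC)c(OC)c(OC)c3)nc12` gives 10800 nM. Compound 2 `CCCc1nn(C)c2c(NC(C)C)nc(/C=C/c3cc(OC)c(OC)c(OC)c3)nc12` gives 3170 nM, and compound 3 `CCCc1nn(C)c2c(NC(C)C)nc(/C=C/c3ccccc3)nc12` gives 12200 nM. Among these three numbers compound 1 holds the second highest. Its nearest neighbour is compound 3, whose value lies within the scatter of that of compound 1, so no order can be read between the two. Compound 2 stands furthest from compound 1, with a lower number that lies beyond the scatter.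

Compound 4 `CCCc1nn(C)c2c(N3CCCC3)nc(-c3cc(OC)c(OC)c(OC)c3)nc12` has not yet been measured. It differs from compound 1 in one place: pyrrolidin-1-yl in place of isopropylamino on an aromatic carbon. Among the measured compounds shown here, no measured pair in this set carries such a change, so nothing in the data tells how large a step it brings or in which direction. Compound 4 is therefore expected to stay close to where compound 1 stands, with an expected step of a 1.1-fold higher number from compound 1 to compound 4 (0.05 log units; within the scatter) that falls within the scatter rather than beyond it. Compound 4 is estimated to give 12000 nM in this assay, with a likely range from 4000 nM to 36000 nM.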

Compound 4, half-maximal inhibitory concentration: "not active" (no number reported)
The entry for compound 4 holds no number, so the estimate cannot be set against anything.
By their numbers in this assay, from the lowest: compound 2; then compounds 1 and 3 (each within the scatter of the next).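

In this assay, among the compounds shown here, compound 4 is reported as "not active" with no number, so no step from compound 1 to compound 4 can be read. Nothing available accounts for this result. The compounds shown leave open how large a step pyrrolidin-1-yl in place of isopropylamino brings on the shared core.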